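A few compounds are considered here, and "the series" means these few. Any claim that something is new, unique, unknown or untested is made for them only; others in the source may bear on it.

In a functional assay on HCT-116 cells (Homo sapiens) for antiproliferative activity, with a stated time of 72 h (a lower number here means a stronger inhibitor, a higher number a weaker inhibitor), compound 3 `Nc1ncnn2c([C@@H]3O[C@H](CO)[C@@H](O)[C@H]3O)cc(-c3ccc(F)cc3)c12` gives 42500 nM and compound 2 `Nc1ncnn2c([C@@H]3O[C@H](CO)[C@@H](O)[C@H]3O)cc(C#Cc3cccs3)c12` gives 65500 nM as its value. These two sit together, with a 1.5-fold lower number from compound 2 to compound 3 (0.19 log units; within the scatter) as their whole gap. Compound 1 `Nc1ncnn2c([C@@H]3O[C@H](CO)[C@@H](O)[C@H]3O)cc(C#Cc3ccc(F)cc3)c12` reports only > 100000 nM as a limit of the assay. Compound 4 `Nc1ncnn2c([C@@H]3O[C@H](CO)[C@@H](O)[C@H]3O)cc(-c3ccc(F)cc3F)c12` differs from compound 3 by fluoro in place of hydrogen on an aromatic carbon with fluoro in place of hydrogen on an aromatic carbon, ortho to a large group and meta to a fluoro group. Among the compounds with values here, no measured step makes this change itself. Swapping the whole group at that place gave an at least 2.3-fold lower number from compound 1 to compound 3 (0.37 log units; beyond the scatter) in one case and a 1.5-fold lower number from compound 2 to compound 3 (0.19 log units; within the scatter) in the other. One added fluoro is a smaller edit than those swaps, so in this assay the expected step is a 1.1-fold lower number from compound 3 to compound 4 (0.03 log units; within the scatter) with no shift beyond the scatter. For compound 4 the estimated value is 40000 nM with 15000 nM to 100000 nM as its range.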

Compound 4, half-maximal inhibitory concentration: 59500 nM
For compound 4 the middle estimate is 1.5-fold (0.17 log units) below the measured one, within the range that was stated.
By their numbers in this assay, from the lowest: compounds 3, 4 and 2 (each within the scatter of the next). At a limit, above all of these: compound 1.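

In this assay, fluoro in place of hydrogen on an aromatic carbon, ortho to a large group and meta to a fluoro group, gives a 1.4-fold higher number from compound 3 to compound 4 (0.15 log units; within the scatter). Setting 2,4-difluorophenyl in place of 2-(thiophen-2-yl)ethynyl gives a 1.1-fold lower number from compound 2 to compound 4 (0.04 log units; within the scatter), so these two groups are not told apart here either. Setting 2,4-difluorophenyl in place of 2-(4-fluorophenyl)ethynyl gives an at least 1.6-fold lower number from compound 1 to compound 4 (0.22 log units; that floor lies within the scatter), and this step rests on a limit: the limit of > 100000 nM in this assay, at which 1 of the 4 values shown sits.

From the compounds shown here alone, whether an amine or a methoxy group on this ring would move the number beyond the scatter stays open.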